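Swapping a morpholine amide for a phenylethyl amide

The compounds below may be only part of what the source reports. "The series", "measured", "known", "first", "only" and "open" are said of these compounds alone.

Of the compounds shown here, three sharing a diaryl urea core have been tested in a functional assay on HT-29 cells (Homo sapiens) for inhibition, read by MTT assay, with a stated time of 120 h; on this read-out higher numbers stand for weaker inhibition and lower numbers for stronger inhibition. Compound 1 `CNC(=O)/C=C/c1ccc(NC(=O)Nc2ccc(Cl)c(C(F)(F)F)c2)cc1` gives 11700 nM. Compound 2 `CC(NC(=O)c1ccc(-c2ccc(NC(=O)Nc3cc(C(F)(F)F)ccc3Cl)cc2)cc1)c1ccccc1` gives 6570 nM, the lowest of the three numbers. Compound 3 `C/C(=C\C(=O)N1CC(C)OC(C)C1)c1ccc(NC(=O)Nc2ccc(Cl)c(C(F)(F)F)c2)cc1` gives 26200 nM, the highest number of the set, a gap beyond the usual scatter from both compound 1 and compound 2.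

Compound 4 `C/C(=C\C(=O)NC(C)c1ccccc1)c1ccc(NC(=O)Nc2ccc(Cl)c(C(F)(F)F)c2)cc1` differs from compound 3 in one place: (1-phenylethyl)amino in place of 2,6-dimethylmorpholin-4-yl on a carbonyl carbon. The entering group already appears in compound 2, where it sits on a carbonyl carbon attached to an aromatic ring rather than to a double-bonded chain carbon, and compound 2 gives 6570 nM. Compound 1 carries a small amide on a related chain and gives 11700 nM. On that basis, a move toward lower numbers in this assay is expected, of modest size. The expected step is a 2.9-fold lower number from compound 3 to compound 4 (0.46 log units; beyond the scatter). Compound 4 is therefore estimated at 9000 nM, with a range from 3000 nM to 27000 nM.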

Compound 4, half-maximal inhibitory concentration: > 50000 nM
Compound 4 ended at the assay's limit (the forecaster's own chance of this, stated with the estimate: 10%); middle value at least 5.5-fold (0.74 log units) away from the limit.
By their numbers in this assay, from the lowest: compounds 2 and 1 (each within the scatter of the next); then compound 3. At a limit, above all of these: compound 4.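

In this assay compound 4 stands at > 50000 nM, which is a limit of the assay and not a number: the limit of > 50000 nM in this assay, at which 1 of the 4 values shown sits. Placing (1-phenylethyl)amino in place of 2,6-dimethylmorpholin-4-yl on this carbonyl carbon gives an at least 1.9-fold higher number from compound 3 to compound 4 (0.28 log units; that floor lies within the scatter), so the true size of the step stays unknown and its floor alone does not separate the two compounds. Among these compounds, this is the first direct reading of the position, as no earlier pair differed in one place, and the exchange brings no move toward lower numbers.

The entering group adds an amide hydrogen and an aromatic ring in one step, and the compounds shown do not tell these two features apart. Also open, on these data alone, is how a carboxylic acid or a plain dimethylamino group on this carbonyl carbon would read.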